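A few compounds are considered here, and "the series" means these few. Any claim that something is new, unique, unknown or untested is made for them only; others in the source may bear on it.

Measured compounds:
compound 1 `CN(C)Cc1ccc2nc(NC(=O)N/N=C/c3cn(Cc4ccc(C(C)(C)C)cc4)c4ccccc34)sc2c1`, 2230 nM in a functional assay on MDA-MB-231 cells (Homo sapiens) for cytotoxicity, read by MTT assay, with a stated time of 72 h; a higher number here means a weaker inhibitor, a lower number a stronger inhibitor
compound 2 `CN(C)Cc1ccc2nc(NC(=O)N/N=C/c3cn(Cc4ccc(Cl)cc4)c4ccccc34)sc2c1`, 880 nM
compound 3 `CC1CCN(Cc2ccc3nc(NC(=O)N/N=C/c4cn(Cc5ccc(Cl)cc5)c5ccccc45)sc3c2)CC1`, 2850 nM

Compound 4 `CC1CCN(Cc2ccc3nc(NC(=O)N/N=C/c4cn(Cc5ccc(C(C)(C)C)cc5)c5ccccc45)sc3c2)CC1` is not yet measured. It differs from compound 3 by tert-butyl in place of chloro on an aromatic carbon. The same change, at the same place, is already seen between compound 2 and compound 1: tert-butyl in place of chloro on an aromatic carbon, with the step of a 2.5-fold higher number from compound 2 to compound 1 (0.40 log units; beyond the scatter). The cores of compound 3 and compound 2 differ by 4-methylpiperidin-1-yl in place of dimethylamino on a saturated chain carbon bound to an aromatic carbon, giving a 3.2-fold higher number from compound 2 to compound 3 (0.51 log units; beyond the scatter), so compound 3 already stands at the high end of the three numbers.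

For compound 4 the expectation rests on compound 3 and on the step from compound 2 to compound 1, which points to a higher number; the expected step is a 2.3-fold higher number from compound 3 to compound 4 (0.36 log units; beyond the scatter). On that basis compound 4 is estimated at 6500 nM, with a range from 2800 nM to 15000 nM.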

Compound 4, half-maximal inhibitory concentration: 3880 nM
The estimate for compound 4 lay 1.7-fold (0.22 log units) above the measured number; measured number inside the range.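

In this assay, tert-butyl in place of chloro gives a 1.4-fold higher number from compound 3 to compound 4 (0.13 log units; within the scatter), and this step agrees with the one on the dimethylamino core: the same change on two cores in this assay, a 2.5-fold higher number (0.40 log units; beyond the scatter) from compound 2 to compound 1 and a 1.4-fold higher number (0.13 log units; within the scatter) from compound 3 to compound 4, 1.9-fold (0.27 log units) apart, within the scatter of two such steps

4-Methylpiperidin-1-yl in place of dimethylamino gives a 1.7-fold higher number from compound 1 to compound 4 (0.24 log units; within the scatter), and this step also agrees with its counterpart on the chloro compounds: the same change on two cores in this assay, a 3.2-fold higher number (0.51 log units; beyond the scatter) from compound 2 to compound 3 and a 1.7-fold higher number (0.24 log units; within the scatter) from compound 1 to compound 4, 1.9-fold (0.27 log units) apart, within the scatter of two such steps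

Each change therefore carries from one core to the other within the scatter, but two cores per change, with both new steps themselves within the scatter, do not establish a fixed step size or a rule for the wider series.

Still open, from the compounds shown here alone, is how a methoxy group or a carboxylic acid in place of chloro would behave. The same holds for a primary amine or a longer alkyl chain in place of dimethylamino.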